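Removing the benzoyl group from compound 3

The compounds below may be only part of what the source reports. "The series", "measured", "known", "first", "only" and "open" are said of these compounds alone.

In a functional assay on MKN-45 cells (Homo sapiens) for cytotoxicity (on this read-out lower numbers stand for stronger inhibition and higher numbers for weaker inhibition), compound 3 `COc1ccc(S(=O)(=O)N2CCc3cccc(NC(=O)c4ccccc4)c32)cc1` gives 250 nM, the higher of the two exact numbers in this series. Compound 2 `COc1ccc(S(=O)(=O)N2CCc3cccc(NC(=O)c4ccncc4)c32)cc1` gives 8.8 nM. Phenyl in place of pyridin-4-yl on the carbonyl carbon gives a 28-fold higher number from compound 2 to compound 3 (1.45 log units; beyond the scatter).

Compound 1 `COc1ccc(S(=O)(=O)N2CCc3cccc(NC(=O)Oc4ccccc4)c32)cc1` reads > 10000 nM, which is a limit of the assay. Phenyl in place of phenoxy on the carbonyl carbon gives an at least 40-fold lower number from compound 1 to compound 3 (1.60 log units; beyond the scatter), and pyridin-4-yl in place of phenoxy gives an at least 1100-fold lower number from compound 1 to compound 2 (3.05 log units; beyond the scatter).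

The next compound is compound 4 `COc1ccc(S(=O)(=O)N2CCc3cccc(N)c32)cc1`, with hydrogen in place of benzoyl on a nitrogen on an aromatic ring. The same difference reads benzamido to amino.

For the measured compounds named here, no measured step removes the carbonyl, so the evidence is indirect. All three steps change only the group on the carbonyl carbon, and all three are large. Losing the whole benzoyl group is therefore expected to give a large step to a higher number in this assay, in the direction of a 28-fold higher number from compound 2 to compound 3 (1.45 log units; beyond the scatter). A reading that is only a limit remains possible. The expected change is a 10-fold higher number from compound 3 to compound 4 (1.00 log units; beyond the scatter). For compound 4 the estimated value is 2500 nM, with an expected range of 600 nM to 10000 nM.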

Compound 4, half-maximal inhibitory concentration: 1200 nM
Estimate against measurement, compound 4: 2.1-fold (0.32 log units) above; the range from low to high includes it.
By their numbers in this assay, from the lowest: compound 2; then compound 3; then compound 4. At a limit, above all of these: compound 1.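

In this assay, the free amine is not the bottom of the series: hydrogen in place of benzoyl gives a 4.8-fold higher number from compound 3 to compound 4 (0.68 log units; beyond the scatter), a modest step, whereas hydrogen in place of (pyridin-4-yl)carbonyl gives a 140-fold higher number from compound 2 to compound 4 (2.13 log units; beyond the scatter), a large one. On this nitrogen, then, benzoyl offers only a modest advantage over hydrogen, and most of the advantage seen with compound 2 goes with the pyridin-4-yl group rather than with acylation as such, while phenoxycarbonyl runs the opposite way, with hydrogen in its place giving an at least 8.3-fold lower number from compound 1 to compound 4 (0.92 log units; beyond the scatter). Compound 1 stands at a limit of the assay, so the size of that last step is only a bound: the limit of > 10000 nM in this assay, at which 1 of the 4 values shown sits.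

The compounds shown leave open whether a small aliphatic acyl group such as acetyl, or a simple methyl on this nitrogen, would read nearer to compound 3 or to compound 4. They also leave open whether the gain depends on the ring nitrogen's place, which a pyridin-3-yl or pyridin-2-yl group on the carbonyl carbon would test.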